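The source may hold more compounds than are shown below. What is called first, only, known or untested is meant among the compounds shown, and "the series" means these compounds.

Compound 1 `CCOCC(COCC)Nc1nc(C)nc2c(-c3ccc(OC)cc3C)c(C)nn12`: 19.3 nM
Compound 2 `CCN(CC)c1nc(C)nc2c(-c3cc(F)c(OC)cc3Cl)c(C)nn12`: 1.64 nM

In an assay on cell membranes for displacement of a labelled ligand from corticotropin-releasing factor receptor 1 (Rattus norvegicus) (a lower number here means a stronger inhibitor, a higher number a weaker inhibitor), compound 1 stands at the higher of the two numbers; compound 2 gives 1.64 nM, a gap beyond the scatter. Compound 3 `COc1ccc(-c2c(C)nn3c(N(CCC#N)C4CC4)nc(C)nc23)c(C)c1` is not yet measured. It differs from compound 1 by (2-cyanoethyl)(cyclopropyl)amino in place of (2-ethoxy-1-(ethoxymethyl)ethyl)amino on an aromatic carbon, on the aromatic carbon between two ring nitrogen atoms. Among the measured compounds shown here, no measured pair shows this change alone, and compound 2 differs from compound 1 in more than one place, so nothing fixes the size of the step. A modest move toward a lower number is expected, a 2.4-fold lower number from compound 1 to compound 3 (0.38 log units; beyond the scatter). Compound 3 is estimated at 8 nM, within 2 nM to 30 nM.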

Compound 3, half-maximal inhibitory concentration: 1.88 nM
Compound 3: middle estimate off by 4.3-fold (0.63 log units), on the high side; measured number below the stated range.
By their numbers in this assay, from the lowest: compounds 2 and 3 (each within the scatter of the next); then compound 1.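

In this assay, the aromatic carbon between two ring nitrogen atoms now has a measured change: (2-cyanoethyl)(cyclopropyl)amino in place of (2-ethoxy-1-(ethoxymethyl)ethyl)amino gives a 10-fold lower number from compound 1 to compound 3 (1.01 log units; beyond the scatter) and is large. This single change removes the hydrogen-bond donor and brings in both a three-membered ring and a nitrile, so the step cannot be assigned to any one of these. No measurement here offers a reason for the step.

Still open, as far as these compounds go, is how the two substituents on the nitrogen contribute separately. A 3-cyanopropyl chain or a 2-hydroxyethyl group alongside the cyclopropyl would help separate them.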